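A few compounds are considered here, and "the series" means these few. Any claim that something is new, unique, unknown or untested is made for them only; others in the source may bear on it.

Going by the values given here, compound 1 `Oc1cccc(-c2cc(-c3ccccc3F)cc(-c3ccccc3O)n2)c1` is the only member of this small set with a numerical result: in a functional assay on DU-145 cells (Homo sapiens) for inhibition (a lower number here means a stronger inhibitor, a higher number a weaker inhibitor), compound 1 gives 35600 nM. Compound 2 `Oc1cccc(-c2cc(-c3cccc(F)c3)cc(-c3ccccc3O)n2)c1` carries the change (3-fluorophenyl in place of 2-fluorophenyl on an aromatic carbon); in this assay compound 2 reaches only the limit > 50000 nM. The step of an at least 1.4-fold higher number from compound 1 to compound 2 (0.14 log units; that floor lies within the scatter) therefore states a floor rather than a size. Compound 3 `Oc1ccc(-c2cc(-c3ccccc3F)cc(-c3ccccc3O)n2)cc1` differs from compound 1 by 4-hydroxyphenyl in place of 3-hydroxyphenyl on an aromatic carbon, and in this assay compound 3 likewise stops at the limit > 50000 nM, so that an at least 1.4-fold higher number from compound 1 to compound 3 (0.14 log units; that floor lies within the scatter) is again a floor. Both floors rest on (the limit of > 50000 nM in this assay, at which 2 of the 3 values shown sit).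

Compound 4 `Oc1ccc(-c2cc(-c3cccc(F)c3)cc(-c3ccccc3O)n2)cc1` is not yet measured. It differs from compound 3 by 3-fluorophenyl in place of 2-fluorophenyl on an aromatic carbon, the same kind of change as from compound 1 to compound 2, though the surroundings differ: here the change sits meta to a 4-hydroxyphenyl group rather than meta to a 3-hydroxyphenyl group. With both neighbours of compound 4 already at the limit, compound 4 is expected to lie at or beyond it, a step that the limit leaves unreadable from compound 3 to compound 4, giving an estimate for compound 4 of 70000 nM within 35000 nM to 200000 nM.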

Compound 4, half-maximal inhibitory concentration: > 50000 nM
Compound 4: only a limit was reported; the forecaster's own chance of this, stated with the estimate: 85%; the middle value is on the limit's open side.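

In this assay compound 4 also stops at a limit, > 50000 nM, so its steps from compound 2 and from compound 3 cannot be read: the limit of > 50000 nM in this assay, at which 3 of the 4 values shown sit.

The compounds shown leave open how far compound 2, compound 3 and compound 4 actually lie from one another, and whether the fluorine position matters when the 4-hydroxyphenyl group is present.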